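The source may report more compounds than this note shows. Statements on the series, on what has been measured and on what is new or still open speak of the compounds shown alone.

Measured compounds: compound 1 `CNC(=O)CCCCCCCn1nc(-c2ccc3oc(N)nc3c2)c2c(N)ncnc21` gives 2900 nM in a functional assay on MDA-MB-231 cells (Homo sapiens) for inhibition, read by MTT assay, with a stated time of 72 h; on this read-out higher numbers stand for weaker inhibition and lower numbers for stronger inhibition; compound 2 `Nc1ncnc2c1c(-c1cnc3[nH]ccc3c1)nn2CCCC(=O)NO` gives > 150000 nM in this assay, a limit of the assay rather than a number; compound 3 `Nc1ncnc2c1c(-c1cnc3[nH]ccc3c1)nn2CCCCCCCCCC(=O)NO` gives 10100 nM in this assay.

Compound 2 stands at the limit of > 150000 nM in this assay, at which 1 of the 3 values shown sits. Compound 4 `Nc1ncnc2c1c(-c1cnc3[nH]ccc3c1)nn2CCCCCCCCC(=O)NO` has not been measured. It differs from compound 2 by 5-(hydroxycarbamoyl)pentyl in place of hydroxycarbamoyl on a saturated chain carbon, three bonds along the chain from an aromatic nitrogen. Among the measured compounds shown here, the one measured step that bears on this change is an at least 14-fold lower number from compound 2 to compound 3 (1.17 log units; beyond the scatter), which lengthened the same chain by one more carbon. A step of similar direction is expected for compound 4, with the number falling strongly, estimated as an at least 10-fold lower number from compound 2 to compound 4 (1.00 log units; beyond the scatter). Compound 4 is therefore expected to give about 15000 nM in this assay, between 5000 nM and 60000 nM.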

Compound 4, half-maximal inhibitory concentration: 11000 nM
For compound 4 the middle estimate is 1.4-fold (0.13 log units) above the measured one; the measured number falls inside the stated range.
By their numbers in this assay, from the lowest: compound 1; then compounds 3 and 4 (each within the scatter of the next). At a limit, above all of these: compound 2.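

Placing 5-(hydroxycarbamoyl)pentyl on the chain already gives an at least 13-fold lower number from compound 2 to compound 4 (1.13 log units; beyond the scatter), so the large drop does not need the full chain of compound 3. The further carbon makes no difference that can be read, with a 1.1-fold higher number from compound 3 to compound 4 (0.04 log units; within the scatter), so these two chain lengths cannot be told apart in this assay. The full size of the drop stays unknown, as compound 2 gives a limit of the assay and not a number: the limit of > 150000 nM in this assay, at which 1 of the 4 values shown sits.

Chains of intermediate length leave open where the drop sets in, and a longer chain leaves open whether the level holds. On these data alone, how a carboxylic acid would read in place of the hydroxycarbamoyl end also remains open.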